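The source may hold more compounds than are shown below. What is called first, only, known or untested is meant among the compounds shown, and "the series" means these compounds.

Compound 1 `COc1nc(N)nc2c1c(-c1ccccc1)cn2[C@@H]1O[C@H](CO)[C@@H](O)[C@H]1O` gives > 20000 nM in a functional assay on HL-60 cells (Homo sapiens) for antiproliferative activity, read by XTT assay, with a stated time of 72 h; on this read-out higher numbers stand for weaker inhibition and lower numbers for stronger inhibition.
Compound 2 `COc1ncnc2c1c(-c1ccccc1)cn2[C@@H]1O[C@H](CO)[C@@H](O)[C@H]1O` gives > 20000 nM.
Compound 3 `Nc1nc(N)c2c(-c3ccccc3)cn([C@@H]3O[C@H](CO)[C@@H](O)[C@H]3O)c2n1` gives > 15000 nM.

Each of these three values is a limit of this assay, not a number. Compound 1 therefore stands at a limit only, and so do the two compounds around it: the limit of > 20000 nM in this assay, at which 2 of the 3 values shown sit, and (the limit of > 15000 nM in this assay, at which 1 of the 3 values shown sits). The two measured steps that start from compound 1 are a step that the two limits leave unreadable from compound 1 to compound 2 and a step that the two limits leave unreadable from compound 1 to compound 3; both run from one limit to another, so neither gives a size in either direction.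

Compound 4 `COc1nc(N)nc2c1c(-c1ccsc1)cn2[C@@H]1O[C@H](CO)[C@@H](O)[C@H]1O` differs from compound 1 in one place: thiophen-3-yl in place of phenyl on an aromatic carbon. For the measured compounds named here, no measured step touches this change, and the steps that do exist around compound 1 were all unreadable, so nothing in these data points to a gain or a loss beyond the scatter. The step of a number no higher from compound 1 to compound 4 (the limit leaves the size open) is expected to be unreadable in the same way. Compound 4 is therefore expected to sit at about 20000 nM, most likely again at a limit, with a range from 8000 nM to 50000 nM.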

Compound 4, half-maximal inhibitory concentration: > 20000 nM
Compound 4 gave a limit, no number (the forecaster's own chance of this, stated with the estimate: 80%); the middle value lies on the limit itself.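

Compound 1 and compound 4 both give a limit rather than a number, so the change from phenyl to thiophen-3-yl yields no readable step. The compounds shown leave open how strongly any of them inhibits these cells, and whether any change matters.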